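Replacing thiophen-2-yl with phenyl on a shared core

The source may report more compounds than this note shows. Statements on the series, on what has been measured and on what is new or still open speak of the compounds shown alone.

In a functional assay on HCT-116 cells (Homo sapiens), read by MTT assay, with a stated time of 72 h (a lower number here means a stronger inhibitor, a higher number a weaker inhibitor), compound 3 `CSc1ncnc2c1c(-c1cccs1)cn2[C@@H]1O[C@H](CO)[C@@H](O)[C@H]1O` gives only a limit, > 20000 nM, and not an actual number. Compound 3 thus stands at the limit of > 20000 nM in this assay, at which 2 of the 3 values shown sit. Going by the values given here, compound 2 `CSc1ncnc2c1c(-c1ccoc1)cn2[C@@H]1O[C@H](CO)[C@@H](O)[C@H]1O` is the only one of the measured compounds with a true number, 40 nM.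

Compound 4 `CSc1ncnc2c1c(-c1ccccc1)cn2[C@@H]1O[C@H](CO)[C@@H](O)[C@H]1O` differs from compound 3 by a single change, phenyl in place of thiophen-2-yl on an aromatic carbon.

Among the compounds with values here, only one measured step bears on this carbon. It is an at least 500-fold higher number from compound 2 to compound 3 (2.69 log units; beyond the scatter), a large step in which thiophen-2-yl took the place of furan-3-yl. The group at this carbon can therefore matter a great deal, and a return to activity cannot be ruled out. Within the data shown here, still, the only true number belongs to the compound with furan-3-yl, which compound 4 lacks.

Compound 1 `COc1ncnc2c1c(-c1ccccc1)cn2[C@@H]1O[C@H](CO)[C@@H](O)[C@H]1O`, which also carries phenyl, gives only a limit, > 20000 nM. Compound 4 is therefore expected to stay at or close to that limit.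

The expected change is a number no higher from compound 3 to compound 4 (the limit leaves the size open), so no step beyond the scatter is expected. For compound 4 the estimated value is 20000 nM, with an expected range from 3000 nM to 20000 nM.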

Compound 4, half-maximal inhibitory concentration: > 20000 nM
Compound 4 gave a limit, no number; the forecaster's own chance of this, stated with the estimate: 75%; the middle value sits exactly at the limit.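

In this assay the new result adds a second group at this carbon that goes with lost activity, with phenyl replacing furan-3-yl: the change gives an at least 500-fold higher number from compound 2 to compound 4 (2.69 log units; beyond the scatter) on the same core. Before, only thiophen-2-yl had been set against furan-3-yl with the methylsulfanyl group held constant, whereas furan-3-yl now stands apart from both a five-membered and a six-membered aromatic ring, so the loss is not peculiar to thiophen-2-yl. Both ends of the steps from compound 3 to compound 4 and from compound 1 to compound 4 are limits, so neither step can be read, and the compounds without a true number cannot be ranked against one another: the limit of > 20000 nM in this assay, at which 3 of the 4 values shown sit.

The compounds shown leave open whether the activity of compound 2 depends on the oxygen atom of its ring or on the point at which that ring is attached, a question that furan-2-yl and thiophen-3-yl at this carbon could help to separate. Going by these compounds, it also remains open whether furan-3-yl would keep that activity with methoxy in place of methylsulfanyl.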